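Swapping the amine on a dithiocarbamate-linked benzamide

The source may hold more compounds than are shown below. What is called first, only, known or untested is meant among the compounds shown, and "the series" means these compounds.

Compounds measured so far:
- compound 1, `Nc1ccccc1NC(=O)c1ccc(CSC(=S)N2CCN(c3ccc(Cl)cc3)CC2)cc1`: 51.2%
- compound 2, `CC1CCN(C(=S)SCc2ccc(C(=O)Nc3ccccc3N)cc2)CC1`: 46.8%
- compound 3, `Nc1ccccc1NC(=O)c1ccc(CSC(=S)N2CCN(C(c3ccccc3)c3ccccc3)CC2)cc1`: 8%

All three share a core in which an aminophenyl benzamide carries a thiocarbonyl group, and they differ only in the amine joined to that thiocarbonyl carbon. In a functional assay on HeLa cells (Homo sapiens) for antiproliferative activity, read by CCK-8 assay, with a stated time of 72 h, tested at 2 uM (on this read-out higher numbers stand for a stronger effect at the one concentration tested and lower numbers for a weaker effect), compound 2 gives 46.8%, which is the second highest of the three numbers. Its nearest neighbour is compound 1, whose value of 51.2% lies within the scatter of compound 2, so the two cannot be told apart. Its furthest neighbour is compound 3, whose value of 8% lies well beyond the scatter below compound 2.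

The next compound, compound 4, `Nc1ccccc1NC(=O)c1ccc(CSC(=S)N2CCc3cc(Cl)ccc32)cc1`, has not yet been measured. It differs from compound 2 in one place: 5-chloro-2,3-dihydro-1H-indol-1-yl in place of 4-methylpiperidin-1-yl on a thiocarbonyl carbon. The entering group, like the group in compound 1, carries a chlorine on a six-membered aromatic ring, whereas the group in compound 3 carries two unsubstituted phenyl rings.

Because compound 1 gives 51.2% and compound 2 gives 46.8%, compound 4 is expected to land near these two, with a step of a number 1.8 percentage points lower from compound 2 to compound 4 (within the scatter) that stays within the scatter. The estimate for compound 4 is 45%, with a range from 25% to 62%.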

Compound 4, a percentage reported as inhibition, at one concentration (the size of the read-out at that concentration, not a potency): 40.1%
Compound 4: the middle estimate sits 4.9 percentage points above what was measured; low and high end bracket the measured number.
By their numbers in this assay, from the lowest: compound 3; then compounds 4, 2 and 1 (each within the scatter of the next, the first and the last beyond it).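

Placing 5-chloro-2,3-dihydro-1H-indol-1-yl in place of 4-methylpiperidin-1-yl on a thiocarbonyl carbon gives, in this assay, a number 6.7 percentage points lower from compound 2 to compound 4 (within the scatter), so the two compounds cannot be told apart. This one-place comparison shows that a group of 10 heavy atoms, with a five-membered non-aromatic ring and a six-membered aromatic ring, can replace a group of 7 heavy atoms with one six-membered non-aromatic ring without a step beyond the scatter, at the one concentration tested. No supporting measurement bears on why the read-out stays within the scatter across this change.

Going by these compounds, it remains open whether the chlorine matters, and a partner of compound 4 carrying unsubstituted 2,3-dihydro-1H-indol-1-yl would separate the chlorine from the ring system that holds it. Also open, on these data alone, is what an open-chain diethylamino group or a morpholin-4-yl ring would give on the same thiocarbonyl carbon, which would test whether this tolerance extends beyond the two groups compared here.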